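Benzylpiperidine amides: nitrooxymethyl versus methyl on the aryl ring

This account rests on a few compounds, and the source may have more. Where it says the series, first, only, none or still open, it means among the compounds named here.

Of the compounds shown here, three have been measured in an assay on isolated protein for displacement of a labelled ligand from Sigma intracellular receptor 2 (Homo sapiens), read by scintillation counting, with a stated time of 1 h, in the presence of a further agent that is not named here; on this read-out higher numbers stand for weaker inhibition and lower numbers for stronger inhibition: compound 1 `O=C(NCCCN1CCC(Cc2ccccc2)CC1)c1ccc(CO[N+](=O)[O-])cc1` gives 230 nM, compound 2 `O=C(NCCCCN1CCC(Cc2ccccc2)CC1)c1ccc(CO[N+](=O)[O-])cc1` gives 89 nM, and compound 3 `O=C(NCCCCCN1CCC(Cc2ccccc2)CC1)c1ccc(CO[N+](=O)[O-])cc1` gives 70 nM. The three share one core and differ only in the saturated chain joining the amide to the rest of the core. On these numbers compound 2 stands second highest of the three; its nearest neighbour is compound 3, whose number sits within the scatter of it, while compound 1 lies further off, beyond the scatter.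

Compound 4 `Cc1ccc(C(=O)NCCCCN2CCC(Cc3ccccc3)CC2)cc1` is not yet measured. It differs from compound 2 by hydrogen in place of nitrooxy on a saturated chain carbon bound to an aromatic carbon. For the measured compounds named here, no measured pair in this set shows that change, so nothing here fixes its size or direction. In this assay the step from compound 2 to compound 4 is expected to be a 1.7-fold higher number from compound 2 to compound 4 (0.23 log units; within the scatter), with a slight lean towards a higher number but not beyond the scatter. For compound 4 the estimate is 150 nM, ranging from 40 nM to 550 nM.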

Compound 4, inhibition constant: 127 nM
Compound 4: the middle estimate sits 1.2-fold (0.07 log units) above what was measured; the range from low to high includes it.
By their numbers in this assay, from the lowest: compounds 3, 2, 4 and 1 (each within the scatter of the next, the first and the last beyond it).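

Nitrooxy to hydrogen at this place, (nitrooxy)methyl to methyl on the aromatic ring, can now be read directly in this assay: the step is a 1.4-fold higher number from compound 2 to compound 4 (0.15 log units; within the scatter), the first reading of any change at this position, as the earlier compounds differed only in the saturated chain. Within the scatter, the nitrooxy group is therefore not needed for the number seen with compound 2, and methyl serves equally well at this place on this chain. No supporting data bear on why the two groups read alike.

Still open, on these data alone, is whether the same change stays this small on the shorter chain of compound 1 or the longer chain of compound 3. Also open, as far as these compounds go, is whether an amine, a carboxylic acid or a nitrile on the same saturated chain carbon would move the number beyond the scatter.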